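Bromo Substitution on the Shared Core

The source may hold more compounds than are shown below. What is called first, only, known or untested is meant among the compounds shown, and "the series" means these compounds.

Measured compounds:
compound 1 `CCCn1c(Br)nc2c(N)nc(NCc3ccccc3)nc21` — 650 nM
compound 2 `CCCn1cnc2c(NCCCc3ccccc3)ncnc21` — 30000 nM

In an assay on CHO cells for displacement of a labelled ligand from transmembrane domain-containing protein TMIGD3 (Homo sapiens) (a lower number here means a stronger inhibitor, a higher number a weaker inhibitor), compound 2 gives the highest of the two numbers; compound 1, the nearest, sits far lower, beyond the scatter. Among the compounds with values here, the two differ in several places at once, so no single step between them can be read.

Compound 3 `CCCn1c(Br)nc2c(NCCCc3ccccc3)ncnc21` carries bromo in place of hydrogen on an aromatic carbon relative to compound 2. Compound 1, which also bears a bromo group, shows a much lower number, but its other changes cloud any lesson. A moderate improvement for compound 3 is expected, a 5.0-fold lower number from compound 2 to compound 3 (0.70 log units; beyond the scatter), and compound 3 is estimated at 6000 nM (range 1500 nM to 20000 nM).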

Compound 3, inhibition constant: 12200 nM
Beside the measured number, compound 3's estimate is 2.0-fold (0.31 log units) below it; low and high end bracket the measured number.
By their numbers in this assay, from the lowest: compound 1; then compound 3; then compound 2.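

In this assay, within the data shown here, bromo in place of hydrogen on an aromatic carbon, between two ring nitrogen atoms, gives a 2.5-fold lower number from compound 2 to compound 3 (0.39 log units; beyond the scatter) and is the first single-place step readable. This position therefore accepts a bromo group, with a modest gain that lies beyond the scatter. No measurement at hand accounts for the step. On these data alone, whether chloro, methyl or an amine at this position would move the number further stays open. So does whether the bromo step would hold with a shorter chain in place of the phenylpropyl amine.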